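The source may report more compounds than this note shows. Statements on the series, on what has been measured and on what is new or still open speak of the compounds shown alone.

In an ADME assay on cells (Fibroblast, Homo sapiens) for cytotoxicity, read by MTT assay, with a stated time of 24 h (a lower number here means a stronger inhibitor, a higher number a weaker inhibitor), two compounds have been measured so far. Compound 1, `O=C(COC(=O)C#Cc1ccccc1)NCCC[Te]c1ccccc1`, gives 7000 nM, the lowest of the two numbers. Compound 2, `COc1ccc(N(CC(=O)NCCCSc2ccccc2)C(=O)CCSC2=C(C)C(=O)c3ccccc3C2=O)cc1`, gives 26000 nM; the gap between compound 1 and compound 2 lies beyond the scatter of repeated measurements, and no single structural change connects the two, so their values simply stand side by side. Compound 3, `O=C(COC(=O)/C=C/c1ccccc1)NCCC[Te]c1ccccc1`, has not yet been measured in this assay. It differs from compound 1 in one place: 2-phenylethenyl in place of 2-phenylethynyl on a carbonyl carbon. The rest of the molecule, including the core of compound 1, is kept. For the measured compounds named here, no pair of measured compounds shows the effect of this change, so no measured step guides the expectation. The step from compound 1 to compound 3 is expected to be small, about a 1.1-fold higher number from compound 1 to compound 3 (0.06 log units; within the scatter), with no clear direction beyond the scatter. Compound 3 is therefore estimated to give about 8000 nM, within 3500 nM to 20000 nM.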

Compound 3, half-maximal inhibitory concentration in the Fibroblast assay: 11000 nM
For compound 3 the middle estimate is 1.4-fold (0.14 log units) below the measured one, within the range that was stated.
By their numbers in the Fibroblast assay, from the lowest: compounds 1 and 3 (each within the scatter of the next); then compound 2.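

For the compounds shown here, in the Fibroblast assay, the single change in structure gives a 1.6-fold higher number from compound 1 to compound 3 (0.20 log units; within the scatter) and so does not separate the two compounds, even though a triple bond has given way to a double bond. In a physicochemical assay for lipophilicity, read by HPLC, measured as octanol-water partition (a higher number here means a more lipophilic compound, a lower number a more polar compound), compound 1 gives 0.9 and compound 3 gives 3.01 in a comparison that shows the same change is far from silent there. For this pair, lipophilicity moves a long way while the cytotoxicity number stays within the scatter: the measured partition coefficient of compound 1, 0.9, and of compound 3, 3.01, a number 2.11 log units higher (beyond the scatter).

As far as these compounds go, whether 2-phenylethyl, with neither a triple nor a double bond outside the ring, would behave like these two groups remains open. So does the effect of a much smaller group at this place, such as methyl, on the number in the Fibroblast assay and on the partition coefficient.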